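A few compounds are considered here, and "the series" means these few. Any claim that something is new, unique, unknown or untested is made for them only; others in the source may bear on it.

Measured compounds:
- Compound 1, `Cc1ccc(Nc2nc(Cl)nc3c2ncn3Cc2ccc(/C=C/C(=O)Nc3ccccc3N)cc2)cc1`: 43%
- Compound 2, `Nc1ccccc1NC(=O)/C=C/c1ccc(Cn2cnc3c(Nc4cccc(Cl)c4)nc(Cl)nc32)cc1`: 49.3%

In a functional assay on HepG2 cells (Homo sapiens) for antiproliferative activity, read by CCK-8 assay, with a stated time of 72 h, tested at 8 uM (on this read-out lower numbers stand for a weaker effect and higher numbers for a stronger effect at the one concentration tested), compound 2 gives the higher of the two numbers, but its nearest neighbour, compound 1, lies within the scatter of it, so the two cannot be ranked. Within the data shown here, the only step among the measured compounds, a number 6.3 percentage points higher from compound 1 to compound 2 (within the scatter), changes the aryl group on the ring nitrogen and stays within the scatter.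

Compound 3, `Nc1ccccc1NC(=O)/C=C/c1ccc(Cn2cnc3c(Nc4cccc(OC(F)(F)F)c4)nc(Cl)nc32)cc1`, differs from compound 2 by trifluoromethoxy in place of chloro on an aromatic carbon. Among the measured compounds shown here, no measured step touches this exact exchange; the one step that bears on it, a number 6.3 percentage points higher from compound 1 to compound 2 (within the scatter), is the only other change at the same aryl group and was within the scatter. On that basis no step beyond the scatter is expected for a number 0.7 percentage points higher from compound 2 to compound 3 (within the scatter) in this assay. Compound 3 is therefore estimated at 50%, with a range from 30% to 70%, because compound 2 gives 49.3% and the comparable change gave a number 6.3 percentage points higher from compound 1 to compound 2 (within the scatter).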

Compound 3, a percentage reported as inhibition, at one concentration (the size of the read-out at that concentration, not a potency): 37.6%
Compound 3: middle estimate off by 12.4 percentage points, on the high side; the range from low to high includes it.
By their numbers in this assay, from the lowest: compounds 3, 1 and 2 (each within the scatter of the next, the first and the last beyond it).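

In this assay, among these compounds, exchanging chloro for trifluoromethoxy on the aromatic carbon gives a number 11.7 percentage points lower from compound 2 to compound 3 (beyond the scatter), the first step beyond the scatter at this aryl group, so the read-out is not indifferent to what sits at this place on the ring. The other step at the same group, a number 5.4 percentage points lower from compound 1 to compound 3 (within the scatter), stays within the scatter, so 3-(trifluoromethoxy)phenyl and 4-methylphenyl cannot be ranked against each other, and of the three compounds only compound 2 and compound 3 can be told apart. The exchange puts a group of 5 heavy atoms in place of a single chlorine, but nothing available gives a reason for the step.

The compounds shown leave open how a methoxy group, a trifluoromethyl group or an amine on the same aromatic carbon would read, so a single exchange cannot yet be extended into a trend at this position. On these data alone, it also remains open how these compounds compare at any other concentration: each number tells only of a stronger or weaker effect at the one concentration tested.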